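Sulfonyl Aryl Swap in a Fluorinated Quinoline Series

A few compounds are considered here, and "the series" means these few. Any claim that something is new, unique, unknown or untested is made for them only; others in the source may bear on it.

The measured compounds and their numbers:
Compound 1, `Cc1ccc(S(=O)(=O)c2cnc3c(F)cccc3c2-c2cccc(F)c2)cc1F`, gives 3.92 mL/min in an ADME assay on microsomes from liver (Homo sapiens) for metabolic stability, tested at 2.5 uM; on this read-out lower numbers stand for slow clearance and higher numbers for fast clearance.
Compound 2, `COc1cccc(-c2c(S(=O)(=O)c3ccc(C)c(F)c3)cnc3c(F)cccc23)c1`, gives 4.02 mL/min in this assay.
Compound 3, `Cc1ccc(S(=O)(=O)c2cnc3c(F)cccc3c2-c2cccc(Cl)c2)cc1F`, gives 3.18 mL/min in this assay.

Compound 1 stands second highest of the three numbers; its nearest neighbour is compound 2, a 1.0-fold higher number from compound 1 to compound 2 (0.01 log units; within the scatter), and its furthest is compound 3, a 1.2-fold lower number from compound 1 to compound 3 (0.09 log units; within the scatter). The remaining measured pair, a 1.3-fold lower number from compound 2 to compound 3 (0.10 log units; within the scatter), is likewise within the scatter, so the three compounds cannot be separated from one another on this read-out.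

The unmeasured compound 4, `O=S(=O)(c1cc(F)cc(F)c1)c1cnc2c(F)cccc2c1-c1cccc(F)c1`, differs from compound 1 as follows: 3,5-difluorophenyl in place of 3-fluoro-4-methylphenyl on a sulfonyl sulfur. Within the data shown here, none of the measured steps touches the group on the sulfonyl sulfur; all three vary the aryl group on the other side of the shared core, and each of them stayed within the scatter. Among the measured compounds shown here, there is therefore no measured step that bears directly on this change, and the only guide is that every substitution tried so far left the number essentially unchanged. Compound 4 is thus expected to show no step beyond the scatter, a 1.1-fold lower number from compound 1 to compound 4 (0.04 log units; within the scatter), and its estimated value in this assay is 3.6 mL/min, with a range from 2 mL/min to 6.5 mL/min.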

Compound 4, intrinsic clearance in a liver preparation (reported as CLH), per the amount of preparation that the assay uses: 1.18 mL/min
Compound 4: the middle estimate sits 3.1-fold (0.48 log units) above what was measured; the whole stated range lies above it.
By their numbers in this assay, from the lowest: compound 4; then compounds 3, 1 and 2 (each within the scatter of the next).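

Among these compounds, the group on the sulfonyl sulfur is the first place where the number in this assay moves clearly: 3,5-difluorophenyl in place of 3-fluoro-4-methylphenyl gives a 3.3-fold lower number from compound 1 to compound 4 (0.52 log units; beyond the scatter) and so stands apart from the three steps on the aryl group at the other side of the shared core, all of which stayed within the scatter. The step comes with no difference in the count of heavy atoms, rings, hydrogen-bond donors or acceptors, or in net charge; the entering group simply has a fluorine where the leaving group has a carbon in its count. Nothing among the data shown accounts for the size of this step.

This one pair does not separate the loss of the methyl from the gain of the second fluorine, and it leaves open whether the same swap would give a step of similar size alongside the chloro-bearing aryl group of compound 3 or the methoxy-bearing aryl group of compound 2. As far as these compounds go, how an unsubstituted phenyl, an aryl group carrying an amine or a longer alkyl chain on the sulfonyl sulfur would read also remains open.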